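Pyrazole replacement on the aryl ether series

This account rests on a few compounds, and the source may have more. Where it says the series, first, only, none or still open, it means among the compounds named here.

Compound 1 `CCCC(Oc1ccc(-n2cc(F)cn2)cc1)c1ccc(C(=O)NCCC(=O)O)cc1` is the starting point. In an assay on cells for displacement of a labelled ligand from Glucagon receptor (Homo sapiens), in the presence of a further agent that is not named here (on this read-out higher numbers stand for weaker inhibition and lower numbers for stronger inhibition), compound 1 gives 1700 nM, the highest of the three numbers measured. Compound 3 `CC(C)(C)C(Oc1ccc(-n2cc(C(F)(F)F)cn2)cc1)c1ccc(C(=O)NCCC(=O)O)cc1` gives 170 nM in this assay, a lower number than compound 1 by a margin beyond the scatter. Going by the values given here, compound 2 `CCCC(Nc1cnc(-n2cc(C(F)(F)F)cn2)nc1)c1ccc(C(=O)NCCC(=O)O)cc1` gives 100 nM, lower again and the furthest from compound 1; no single-point step connects any of these pairs, so the values are read only side by side.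

Compound 4 `CCCC(Oc1ccc(-n2cc3c(n2)CCCC3)cc1)c1ccc(C(=O)NCCC(=O)O)cc1` is not yet measured. Its change from compound 1: a group of 9 heavy atoms (7 carbon, 2 nitrogen; one five-membered aromatic ring with 2 hetero atoms, one six-membered non-aromatic ring of carbon only) in place of a group of 6 heavy atoms (3 carbon, 2 nitrogen, 1 fluorine; one five-membered aromatic ring with 2 hetero atoms), on an aromatic carbon

Among the compounds with values here, no measured step isolates a change of this kind. Within the data shown here, the only guide is that compound 1, with the smallest group on the pyrazole, sits at the high end of the numbers seen, while compound 3 with a trifluoromethyl group sits at 170 nM. The expected step of a 3.4-fold lower number from compound 1 to compound 4 (0.53 log units; beyond the scatter) is therefore toward a lower number, of moderate size, though a result within the scatter cannot be excluded. Compound 4 is estimated at 500 nM in this assay, within a range from 150 nM to 2000 nM.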

Compound 4, inhibition constant: 690 nM
Compound 4: middle estimate off by 1.4-fold (0.14 log units), on the low side, and the stated range covers the measured number.
By their numbers in this assay, from the lowest: compounds 2 and 3 (each within the scatter of the next); then compound 4; then compound 1.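

Going by these compounds alone, at this place, on an aromatic carbon para to a large group, exchanging the 4-fluoro-1H-pyrazol-1-yl group for the group with a six-membered non-aromatic ring of carbon only gives in this assay a 2.5-fold lower number from compound 1 to compound 4 (0.39 log units; beyond the scatter) and is the first step that can be read at a single place. The larger group, with 9 heavy atoms in place of 6, is therefore accepted here without a rise in the number, and the count of hydrogen-bond donors and acceptors stays the same. No supporting measurement bears on why the number moves.

Going by these compounds, whether the added ring or size alone goes with the lower number stays open, as does how a methyl group or a nitrile on the pyrazole would compare with the fluorine of compound 1. Compound 2 and compound 3 differ from compound 1 in more than one place, so the trifluoromethyl group at this position cannot be read on its own from them.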